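A few compounds are considered here, and "the series" means these few. Any claim that something is new, unique, unknown or untested is made for them only; others in the source may bear on it.

Working notes on the series. Compound 2 `CN1CCN(c2ccc(Nc3ncc4nc(Nc5ccc(F)cc5)n([C@@H]5CCN(C(=O)OC(C)(C)C)C5)c4n3)cc2)CC1` serves as the reference; in a functional assay on HCC827 cells (Homo sapiens) for antiproliferative activity, read by MTT assay, with a stated time of 72 h (on this read-out lower numbers stand for stronger inhibition and higher numbers for weaker inhibition), compound 2 gives 27 nM. Compound 1 `CNC(=O)CN1CC[C@H](n2c(Nc3ccc(F)cc3)nc3cnc(Nc4ccc(N5CCN(C)CC5)cc4)nc32)C1` differs from compound 2 by 1-((methylcarbamoyl)methyl)pyrrolidin-3-yl in place of 1-(tert-butoxycarbonyl)pyrrolidin-3-yl on an aromatic nitrogen. In this assay compound 1 gives 1520 nM, which is a 56-fold higher number from compound 2 to compound 1 (1.75 log units; beyond the scatter). Compound 3 `CN1CCN(c2ccc(Nc3ncc4nc(Nc5ccccc5)n([C@@H]5CCN(C(=O)OC(C)(C)C)C5)c4n3)cc2)CC1` differs from compound 2 by hydrogen in place of fluoro on an aromatic carbon; in this assay compound 3 gives 12 nM, which is a 2.3-fold lower number from compound 2 to compound 3 (0.35 log units; beyond the scatter). Among the three measured compounds compound 3 carries the lowest number, and its steps to compound 2 and to compound 1 are both beyond the scatter.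

Compound 4 `CNC(=O)CN1CC[C@H](n2c(Nc3ccccc3)nc3cnc(Nc4ccc(N5CCN(C)CC5)cc4)nc32)C1` has not yet been measured. It differs from compound 3 by 1-((methylcarbamoyl)methyl)pyrrolidin-3-yl in place of 1-(tert-butoxycarbonyl)pyrrolidin-3-yl on an aromatic nitrogen. This is the same kind of change as that made from compound 2 to compound 1, and it occurs twice in all among the compounds shown, but the surroundings are not identical: in compound 3 and compound 4 the ring atom next to the aromatic nitrogen bears an anilino group (7 heavy atoms), whereas in compound 2 and compound 1 it bears a (4-fluorophenyl)amino group (8 heavy atoms). Going by the values given here, only one measured instance of this change exists, so no pattern beyond it can be claimed.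

The step from compound 3 to compound 4 is expected to be a 56-fold higher number from compound 3 to compound 4 (1.75 log units; beyond the scatter), of roughly the size seen as a 56-fold higher number from compound 2 to compound 1 (1.75 log units; beyond the scatter), resting on that single measured step. Compound 4 is therefore estimated to give about 670 nM in this assay, with a likely range from 250 nM to 2000 nM.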

Compound 4, half-maximal inhibitory concentration: 170 nM
For compound 4 the middle estimate is 3.9-fold (0.60 log units) above the measured one, and the stated range ends above it.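

In this assay the 1-((methylcarbamoyl)methyl)pyrrolidin-3-yl group again gives a higher number than the 1-(tert-butoxycarbonyl)pyrrolidin-3-yl group, now as a 14-fold higher number from compound 3 to compound 4 (1.15 log units; beyond the scatter), so the direction holds in both pairs, but the size does not carry over from one core to the other: the same change on two cores in this assay, a 56-fold higher number (1.75 log units; beyond the scatter) from compound 2 to compound 1 and a 14-fold higher number (1.15 log units; beyond the scatter) from compound 3 to compound 4, 4.0-fold (0.60 log units) apart, beyond the scatter of two such steps.

Seen from the other side, hydrogen in place of fluoro gives a lower number in both pairs, here as an 8.9-fold lower number from compound 1 to compound 4 (0.95 log units; beyond the scatter), and again the size depends on the surroundings: the same change on two cores in this assay, a 2.3-fold lower number (0.35 log units; beyond the scatter) from compound 2 to compound 3 and an 8.9-fold lower number (0.95 log units; beyond the scatter) from compound 1 to compound 4, 4.0-fold (0.60 log units) apart, beyond the scatter of two such steps.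

These two gaps come from the same four compounds and so record a single departure from additivity, not two separate findings; they show that the two changes do not act independently here, but they do not show why, nor whether either step size is typical of the series.

Still open, from the compounds shown here alone, is whether the same direction would hold with a free secondary amine, an acetyl group or a longer chain on the pyrrolidine nitrogen. Also open, going by these compounds, is how the two changes would combine with chloro or methoxy in place of fluoro on the anilino group.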